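Two aryl groups on the core nitrogen, a third pending

The source may hold more compounds than are shown below. What is called first, only, known or untested is meant among the compounds shown, and "the series" means these compounds.

compound 1 `O=C(Nc1ccc(Oc2ccnc3[nH]ccc23)cc1)c1cc2cccnc2n(-c2ccc(Cl)cc2)c1=O`: 3370 nM
compound 2 `COc1ccc(-n2c(=O)c(C(=O)Nc3ccc(Oc4ccnc5[nH]ccc45)cc3)cc3cccnc32)cc1`: 2350 nM

In a functional assay on U-87MG ATCC cells for antiproliferative activity against U-87 MG (Homo sapiens), read by MTT assay, with a stated time of 72 h (on this read-out lower numbers stand for stronger inhibition and higher numbers for weaker inhibition), compound 2 stands together with compound 1, since a 1.4-fold lower number from compound 1 to compound 2 (0.16 log units; within the scatter) does not separate the two numbers. Compound 3 `O=C(Nc1ccc(Oc2ccnc3[nH]ccc23)cc1)c1cc2cccnc2n(-c2ccc(C(F)(F)F)cc2Cl)c1=O` brings (2-chloro-4-(trifluoromethyl)phenyl in place of 4-methoxyphenyl on an aromatic nitrogen). Among the compounds with values here, the only measured step, a 1.4-fold lower number from compound 1 to compound 2 (0.16 log units; within the scatter), exchanged a group at the same nitrogen and stayed within the scatter; no step of the present size, which also removes the one acceptor, has been measured. Compound 3 is therefore expected close to compound 2, with an expected step of a 1.1-fold higher number from compound 2 to compound 3 (0.03 log units; within the scatter), not beyond the scatter. The estimate for compound 3 is 2500 nM, with a range from 900 nM to 7000 nM.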

Compound 3, half-maximal inhibitory concentration: 6030 nM
For compound 3 the middle estimate is 2.4-fold (0.38 log units) below the measured one, and the stated range covers the measured number.
By their numbers in this assay, from the lowest: compounds 2, 1 and 3 (each within the scatter of the next, the first and the last beyond it).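

In this assay, this aryl position on the core nitrogen now gives a change beyond the scatter (a 2.6-fold higher number from compound 2 to compound 3 (0.41 log units; beyond the scatter)) with 2-chloro-4-(trifluoromethyl)phenyl in place of 4-methoxyphenyl. Measured against 4-chlorophenyl, the same group stays within the scatter (a 1.8-fold higher number from compound 1 to compound 3 (0.25 log units; within the scatter)), so the modest separation holds only against the 4-methoxyphenyl compound. No available evidence bears on the cause of either step.

The chloro and trifluoromethyl groups enter together, leaving their separate contributions open. Also open, as far as these compounds go, is how an amine or a carboxylic acid on this aryl ring would read.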